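Moving a methyl from chain carbon to amide nitrogen

The source may hold more compounds than are shown below. What is called first, only, known or untested is meant among the compounds shown, and "the series" means these compounds.

Compound 1: `C[C@](NC(=O)[C@H](CCCCN)NC(=O)[C@H](CCCNC(=N)N)NC(=O)c1ccccc1)(C(N)=O)c1ccccc1` — 11.8%
Compound 2: `C[C@@](NC(=O)[C@H](CCCCN)NC(=O)[C@H](CCCNC(=N)N)NC(=O)c1ccccc1)(C(N)=O)c1ccccc1` — 20.7%

Two compounds have been run in an assay on isolated protein for inhibition of Trypsin (Homo sapiens), read by fluorescence, with a stated time of 15 min, tested at 50 uM; on this read-out higher numbers stand for more inhibition at the one concentration tested (going by the name of the read-out) and lower numbers for less inhibition. Compound 1 gives 11.8% and compound 2 gives 20.7%. Among the measured compounds shown here, the only measured step, a number 8.9 percentage points higher from compound 1 to compound 2 (within the scatter), is within the scatter, so the two numbers are not distinguishable; compound 2 simply holds the higher of the two figures, with compound 1 its nearest neighbour.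

Compound 3, `CN(C(=O)[C@H](CCCCN)NC(=O)[C@H](CCCNC(=N)N)NC(=O)c1ccccc1)[C@@H](C(N)=O)c1ccccc1`, is not yet measured. It differs from compound 2 in that ((carbamoyl(phenyl)methyl)(methyl)amino in place of (1-carbamoyl-1-phenylethyl)amino on a carbonyl carbon). For the measured compounds named here, no measured step changes the atoms joined this way, so nothing among the known numbers speaks directly to this change; the one step available was a stereochemical swap and stayed within the scatter. The expectation for compound 3 in this assay is therefore modest: a step of a number 5.7 percentage points lower from compound 2 to compound 3 (within the scatter) is estimated, with no clear direction beyond the scatter. Compound 3 is expected to give 15%, within 0% to 40%.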

Compound 3, a percentage reported as inhibition, at one concentration (the size of the read-out at that concentration, not a potency): <= 5%
Compound 3 gave a limit, no number (the forecaster's own chance of this, stated with the estimate: 5%); middle value at least 10 percentage points away from the limit.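

In this assay the figure for compound 3, <= 5%, is a limit of the assay and not a number. Where the stereochemical swap stayed within the scatter, replacing (1-carbamoyl-1-phenylethyl)amino with (carbamoyl(phenyl)methyl)(methyl)amino on a carbonyl carbon gives the first step beyond it: a number at least 15.7 percentage points lower from compound 2 to compound 3 (beyond the scatter). The same replacement read against the other stereoisomer gives a number at least 6.8 percentage points lower from compound 1 to compound 3 (that floor lies within the scatter), so the number in this assay is lower beyond the scatter only on the step that starts from compound 2.

The compounds shown leave open whether the entering group's count of 1 hydrogen-bond donor, against 2 in the leaving group, has any bearing on this step. They also leave open how an ethyl in place of the methyl of (carbamoyl(phenyl)methyl)(methyl)amino would read.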